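Adding a nitro to compound 2: working notes

This account rests on a few compounds, and the source may have more. Where it says the series, first, only, none or still open, it means among the compounds named here.

Values so far in an ADME assay on MDBK cells (Bos taurus) for cytotoxicity, read by MTT assay, with a stated time of 96 h; on this read-out lower numbers stand for higher toxicity in this test and higher numbers for lower toxicity in this test
- compound 1 `O=[N+]([O-])c1ccc(-c2nc3ccccc3[nH]2)c([N+](=O)[O-])c1` gives 20000 nM
- compound 2 `O=[N+]([O-])c1ccc(-c2nc3cc(C(F)(F)F)ccc3[nH]2)cc1` gives 6000 nM

Of the two measured compounds, compound 2 (6000 nM) has the lower number, and its gap to compound 1 lies beyond the usual scatter. Compound 3 `O=[N+]([O-])c1ccc(-c2nc3cc(C(F)(F)F)ccc3[nH]2)c([N+](=O)[O-])c1` is compound 2 with nitro in place of hydrogen on an aromatic carbon, ortho to a large group and meta to a nitro group (nitro in place of hydrogen on an aromatic carbon). Among the measured compounds shown here, no measured pair isolates this change, so any expectation in this assay remains loose. Compound 1, which also carries this added nitro, gives the higher number (20000 nM), and this points to a modest upward move. The expected step (a 1.5-fold higher number from compound 2 to compound 3 (0.18 log units; within the scatter)) is small and may stay within the scatter. For compound 3 the estimated value is 9000 nM (expected range 3500 nM to 22000 nM).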

Compound 3, half-maximal cytotoxic concentration: 16000 nM
Estimate against measurement, compound 3: 1.8-fold (0.25 log units) below, within the range that was stated.
By their numbers in this assay, from the lowest: compound 2; then compounds 3 and 1 (each within the scatter of the next).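

Working notes on the added nitro: in this assay this change now has a measured pair of its own, with nitro in place of hydrogen on an aromatic carbon, ortho to a large group and meta to a nitro group, giving a 2.7-fold higher number from compound 2 to compound 3 (0.43 log units; beyond the scatter). With that nitro present, adding the trifluoromethyl gives a 1.3-fold lower number from compound 1 to compound 3 (0.10 log units; within the scatter), so this pair is not separated in this test. No measured data available here explain the nitro step.

On these data alone, whether an amine or a carboxylic acid in this same position would give a number close to that of compound 3 remains open. Also open, as far as these compounds go, is whether the nitro step carries over to a core without trifluoromethyl.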